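Cytotoxicity notes: piperazine-capping step in the cyanovinyl series

This account rests on a few compounds, and the source may have more. Where it says the series, first, only, none or still open, it means among the compounds named here.

Measured so far:
- compound 1, `Cc1cc(/C=C/C#N)cc(C)c1Oc1nc(Nc2ccc(CN3CCN(S(C)(=O)=O)CC3)cc2)nc2ccsc12`: 20700 nM
- compound 2, `Cc1cc(/C=C/C#N)cc(C)c1Oc1nc(Nc2ccc(N3CCNCC3)cc2)nc2ccsc12`: 5730 nM

In an ADME assay on MT4 cells (Homo sapiens) for cytotoxicity, read by MTT assay, with a stated time of 5 days (on this read-out higher numbers stand for lower toxicity in this test and lower numbers for higher toxicity in this test), compound 2 gives 5730 nM and stands lowest of the two numbers, with compound 1 the nearest neighbour at a higher number. Compound 3, `Cc1cc(/C=C/C#N)cc(C)c1Oc1nc(Nc2ccc(N3CCN(S(C)(=O)=O)CC3)cc2)nc2ccsc12`, differs from compound 2 by methylsulfonyl in place of hydrogen on an amine nitrogen in a ring. For the measured compounds named here, the only step in hand, a 3.6-fold lower number from compound 1 to compound 2 (0.56 log units; beyond the scatter), removed this same methylsulfonyl together with a linking methylene and moved the number downward beyond the scatter. Restoring the methylsulfonyl alone is therefore expected to move the number back upward by about a 2.1-fold higher number from compound 2 to compound 3 (0.32 log units; beyond the scatter), though the missing methylene keeps the size uncertain. Compound 3 is estimated at 12000 nM, with a range from 5500 nM to 30000 nM.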

Compound 3, half-maximal cytotoxic concentration: 11500 nM
Estimate against measurement, compound 3: 1.0-fold (0.02 log units) above, and the stated range covers the measured number.
By their numbers in this assay, from the lowest: compounds 2, 3 and 1 (each within the scatter of the next, the first and the last beyond it).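

In this assay, methylsulfonyl on the ring amine nitrogen, taken alone, stays within the scatter (a 2.0-fold higher number from compound 2 to compound 3 (0.30 log units; within the scatter)), and so does removing the linking methylene with the methylsulfonyl kept (a 1.8-fold lower number from compound 1 to compound 3 (0.26 log units; within the scatter)). Only the two changes together clear the scatter (a 3.6-fold lower number from compound 1 to compound 2 (0.56 log units; beyond the scatter)), so neither one can be singled out as the source of that step. Nothing available bears on the reason for these steps.

Still open, as far as these compounds go, is how an acetyl group, a carboxylic acid or a longer alkyl chain on this nitrogen would read. Also open, from the compounds shown here alone, is the effect of the methylene with hydrogen on that nitrogen.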